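The compounds below may be only part of what the source reports. "The series", "measured", "known", "first", "only" and "open" are said of these compounds alone.

Measured so far in a functional assay on NCI-H460 cells (Homo sapiens) for antiproliferative activity, read by MTT assay, with a stated time of 48 h; on this read-out lower numbers stand for stronger inhibition and higher numbers for weaker inhibition:
- Compound 1 `COc1cccc(-c2nc3cccc(-c4cc(OC)c(OC)c(OC)c4)c3o2)c1` gives > 25000 nM as a limit, not a number
- Compound 2 `COc1ccc(-c2nc3cccc(-c4cc(OC)c(OC)c(OC)c4)c3o2)cc1OC` gives > 25000 nM as a limit, not a number
- Compound 3 `COc1ccc(-c2nc3cccc(-c4cc(OC)c(OC)c(OC)c4)c3o2)cc1F` gives 2800 nM as a true number

Compound 3 alone gives a true number; the others stop at a shared limit (the limit of > 25000 nM in this assay, at which 2 of the 3 values shown sit). Compound 4 `COc1cc(-c2cccc3nc(-c4ccc(Br)cc4)oc23)cc(OC)c1OC` keeps the shared core but carries 4-bromophenyl in place of 3-fluoro-4-methoxyphenyl (4-bromophenyl in place of 3-fluoro-4-methoxyphenyl on an aromatic carbon) on an aromatic carbon of the five-membered aromatic ring with 1 nitrogen and 1 oxygen.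

The measured steps that bear on this are an at least 8.9-fold lower number from compound 1 to compound 3 (0.95 log units; beyond the scatter) and also an at least 8.9-fold lower number from compound 2 to compound 3 (0.95 log units; beyond the scatter) at the same phenyl group. Both give only a minimum size, and neither involves bromine, so the size of the new step remains uncertain. The remaining one is a step that the two limits leave unreadable from compound 1 to compound 2 and gives no size to use. Compound 3 reached 2800 nM with the group that compound 4 gives up, so a higher number, meaning weaker inhibition, is expected in this assay for compound 4. The expected change is a 2.9-fold higher number from compound 3 to compound 4 (0.46 log units; beyond the scatter) and remains only an estimate. For compound 4 the estimated value is 8000 nM with 2000 nM to 30000 nM as the expected range.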

Compound 4, half-maximal inhibitory concentration: > 25000 nM
Compound 4 ended at the assay's limit (the forecaster's own chance of this, stated with the estimate: 30%); middle value at least 3.1-fold (0.49 log units) away from the limit.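

In this assay, putting 4-bromophenyl in place of 3-fluoro-4-methoxyphenyl on this aromatic carbon of the five-membered ring gives an at least 8.9-fold higher number from compound 3 to compound 4 (0.95 log units; beyond the scatter), so a halogen on the phenyl ring does not by itself secure a measurable value: compound 3 carries fluorine and compound 4 carries bromine. Of the four phenyl groups now shown at this position, only the 3-fluoro-4-methoxyphenyl of compound 3 gives a true number, while methoxy groups alone in compound 1 and compound 2 and bromine alone in compound 4 do not. The steps among compound 1, compound 2 and compound 4 cannot be read, because all three stop at the same limit and so cannot be ranked against each other: the limit of > 25000 nM in this assay, at which 3 of the 4 values shown sit.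

This step removes fluorine and methoxy and adds bromine all at once, so it cannot show which of these changes matters. Simpler groups such as 3-fluorophenyl and 4-methoxyphenyl could separate the fluorine from the methoxy, and an amine on the phenyl ring remains an open question at this position.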